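Chloro on the Phenylcarbamoyl Ring: What Compound 4 Should Show

A few compounds are considered here, and "the series" means these few. Any claim that something is new, unique, unknown or untested is made for them only; others in the source may bear on it.

In a functional assay on NCI-H460 cells (Homo sapiens) for inhibition, read by MTT assay, with a stated time of 24 h, tested at 1 ug/mL (a lower number here means less inhibition of growth, a higher number more inhibition of growth at the concentration tested), compound 1 `O=C(CCCCC(S)CCS)Nc1ccccc1` gives 4.3%. Compound 2 `O=C(CCCCC(S)CCS)Nc1ccc(Cl)cc1` carries chloro in place of hydrogen on an aromatic carbon, and in this assay compound 2 gives 6.76%; the step is a number 2.5 percentage points higher from compound 1 to compound 2 (within the scatter). Compound 3 `O=C(CCCCC(CCSC(=O)c1ccccc1)SC(=O)c1ccccc1)Nc1ccccc1` keeps the phenylcarbamoyl end of compound 1 but the difference between the two cores is not broken down here. In this assay compound 3 gives 5.93%. Compound 4 `O=C(CCCCC(CCSC(=O)c1ccccc1)SC(=O)c1ccccc1)Nc1ccccc1Cl`, not yet measured, carries chloro in place of hydrogen on an aromatic carbon. This is the same kind of change as that from compound 1 to compound 2, yet the place differs: para to a large group there, ortho to a large group here. The expected step, resting on the earlier change a number 2.5 percentage points higher from compound 1 to compound 2 (within the scatter), is a number 1.1 percentage points higher from compound 3 to compound 4 (within the scatter). Compound 4 is therefore estimated at 7%, between 0% and 18%.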

Compound 4, percent growth inhibition at one concentration: 14.4%
Compound 4: middle estimate off by 7.4 percentage points, on the low side, and the stated range covers the measured number.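

In this assay, the new step with chloro in place of hydrogen is a number 8.5 percentage points higher from compound 3 to compound 4 (within the scatter), and it does not differ from the earlier step beyond the scatter: the same change on two cores in this assay, a number 2.5 percentage points higher (within the scatter) from compound 1 to compound 2 and a number 8.5 percentage points higher (within the scatter) from compound 3 to compound 4, 6 percentage points apart, within the scatter of two such steps

The change therefore carries from the core of compound 1 to the core of compound 3 with no measurable difference, yet each step is itself within the scatter, so neither shows that the chloro alters growth inhibition at all. The chloro also changes place, standing ortho to a large group in compound 4, so any effect of core and of place cannot be told apart.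

Going by these compounds, whether a bromo or a methoxy group on the same ring would give a step of another size stays open. So does how a chloro ortho to a large group would read on the core of compound 1.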